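Chloro on the aryl ring of two tetrazole cores

The compounds below may be only part of what the source reports. "The series", "measured", "known", "first", "only" and "open" are said of these compounds alone.

Measured in an ADME assay on S9 fraction from liver (Rattus norvegicus) for metabolic stability, read by LC-MS, using NADPH, with a stated time of 30 min; a higher number here means that more of the compound is left, a lower number that less of the compound is left:
- compound 1 `CCCCCCCCc1ccc(OCC(=O)Cn2nnc(-c3ccccc3)n2)cc1`: 33%
- compound 2 `CCCCCCCCc1ccc(OCC(=O)Cn2nnc(-c3ccccc3Cl)n2)cc1`: 28%
- compound 3 `CCCCCCCCc1ccc(OCC(=O)Cn2nnnc2-c2ccccc2)cc1`: 36%

Compound 1 and compound 2 share one core and differ by chloro in place of hydrogen on an aromatic carbon. In this assay the step of a number 5 percentage points lower from compound 1 to compound 2 (within the scatter) was recorded. Compound 3 is built from the same atoms as compound 1, joined differently; the difference between the two cores is not broken down here. Its value in this assay and that of compound 1 lie within the scatter of each other, and so do its value and that of compound 2, so no order among the three is claimed.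

Compound 4 `CCCCCCCCc1ccc(OCC(=O)Cn2nnnc2-c2ccc(Cl)cc2)cc1` has not yet been measured. It differs from compound 3 by chloro in place of hydrogen on an aromatic carbon. This is the same kind of change as from compound 1 to compound 2, but not the same: there the chloro sits ortho to a large group, here para to a large group, and the cores differ as well. Among the compounds with values here, the expected step of a number 5 percentage points lower from compound 3 to compound 4 (within the scatter) is set beside the earlier one because the only measured step of this kind, a number 5 percentage points lower from compound 1 to compound 2 (within the scatter), lies within the scatter. On this basis compound 4 is estimated to give 31% in this assay, with the range from 21% to 41% expected to hold most repeat measurements.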

Compound 4, percent of the compound remaining: 45%
Estimate against measurement, compound 4: 14 percentage points below; the measured number lies above the stated range.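

In this assay the exchange of hydrogen for chloro on the core of compound 3 gave a number 9 percentage points higher from compound 3 to compound 4 (within the scatter) and so, like the earlier step on the core of compound 1, it does not stand clear of the usual scatter. Although the two steps carry opposite signs as printed, they cannot be told apart: the same change on two cores in this assay, a number 5 percentage points lower (within the scatter) from compound 1 to compound 2 and a number 9 percentage points higher (within the scatter) from compound 3 to compound 4, 14 percentage points apart, within the scatter of two such steps. Within the data shown here, this shows that the two measured pairs give no sign of a difference between the cores for this change, but it does not show that the change carries over from one core to the other, nor that it has any real effect on the percentage of compound remaining on either core, and the comparison is further limited by the chloro occupying a different place in each pair, with only the pair on the core of compound 3 having it para to a large group.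

The compounds shown leave open how the 4-chlorophenyl group would read on the core of compound 1, and what a fluoro group, a methoxy group, a nitrile or a carboxylic acid would give in place of the chloro on either core. They also leave open what a shorter chain in place of the octyl chain, or an alcohol in place of the carbonyl, would give in this measurement.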